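Inverting one ring stereocentre in a stalled inhibitor series

The source may hold more compounds than are shown below. What is called first, only, known or untested is meant among the compounds shown, and "the series" means these compounds.

Measured compounds:
- compound 1 `CCOC(=O)/C=C/n1cnc2c(N)ncnc21`: 100000 nM
- compound 2 `Cc1cn([C@H]2C[C@H](O)[C@@H](CO)O2)c(=O)n(/C=C/C=O)c1=O`: 15000 nM
- compound 3 `Cc1cn([C@@H]2O[C@H](CO)[C@@H](O)[C@H]2O)c(=O)n(/C=C/C=O)c1=O`: > 100000 nM

In a functional assay on HeLa cells (Homo sapiens) for inhibition (a higher number here means a weaker inhibitor, a lower number a stronger inhibitor), compound 1 gives 100000 nM. In this assay compound 2 gives 15000 nM. For compound 3 this assay reports only a limit, > 100000 nM, and not a number. Among the measured compounds shown here, the one step that runs between measured compounds is an at least 6.6-fold higher number from compound 2 to compound 3 (0.82 log units; beyond the scatter); it is shaped by the limit of > 100000 nM in this assay, at which 1 of the 3 values shown sits.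

Compound 4 `Cc1cn([C@@H]2O[C@H](CO)[C@@H](O)[C@@H]2O)c(=O)n(/C=C/C=O)c1=O` has not yet been measured in this assay. It differs from compound 3 in this way: the two compounds have the same atoms and bonds and differ only in configuration as drawn: 1 of 5 stereo elements differ; a stereocentre at a saturated ring carbon is drawn R in compound 3 and S in compound 4. For the measured compounds named here, no measured step involves such an inversion of configuration, so none bears directly on it; the only step available concerns a different change. Compound 3 stands at the limit of this assay, and the configuration change gives no ground to expect a number clearly inside the measurable range. Compound 4 is therefore expected to give about 100000 nM, between 50000 nM and 300000 nM, most likely again as a limit. The step expected from this is a number no higher from compound 3 to compound 4 (the limit leaves the size open), not beyond the scatter.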

Compound 4, half-maximal inhibitory concentration: > 100000 nM
Compound 4: no number, only a limit; the forecaster's own chance of this, stated with the estimate: 75%; the middle value lies on the limit itself.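

In this assay compound 4 gives > 100000 nM, which is a limit of the assay and not a number. The hydroxy in place of hydrogen on a saturated ring carbon again gives an at least 6.6-fold higher number from compound 2 to compound 4 (0.82 log units; beyond the scatter), so the weakening seen earlier holds with the inverted stereocentre drawn either way. The step between the two configurations cannot be read, and neither can be placed ahead of the other: the limit of > 100000 nM in this assay, at which 2 of the 4 values shown sit.

Going by these compounds, how far either configuration lies past the limit, and whether the two differ at all in this assay, stays open. Also open, on these data alone, is whether an amine, a methoxy group or a fluorine in place of that hydroxy would bring the number back inside the measurable range, at either configuration of this ring carbon.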